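The compounds below may be only part of what the source reports. "The series", "measured", "known", "first", "only" and "open" are said of these compounds alone.

Among the measured compounds shown here, compound 1 `Cc1cc(NS(=O)(=O)c2ccc(N/C=C\C(=O)c3cc4ccccc4oc3=O)cc2)on1` is one of two compounds measured in a functional assay on T47D cells (Homo sapiens) for cytotoxicity, read by sulforhodamine B assay, with a stated time of 48 h (a lower number here means a stronger inhibitor, a higher number a weaker inhibitor), where compound 1 gives 75600 nM, the higher of the two numbers. Compound 2 `O=C(/C=C\Nc1ccc(S(=O)(=O)Nc2ncccn2)cc1)c1cc2ccccc2oc1=O` gives 75200 nM in this assay, and the step of a 1.0-fold lower number from compound 1 to compound 2 (0.00 log units; within the scatter) shows that swapping the group on the sulfonamide nitrogen left the result unchanged within the scatter. Compound 3 `COc1cnc(NS(=O)(=O)c2ccc(N/C=C\C(=O)c3cc4ccccc4oc3=O)cc2)nc1` has not yet been measured. It differs from compound 1 in one place: 5-methoxypyrimidin-2-yl in place of 3-methyl-1,2-oxazol-5-yl on a sulfonamide nitrogen. For the measured compounds named here, the only step that bears on this is the one from compound 1 to compound 2, which also replaced the same group with a pyrimidine ring and was within the scatter. Going by the values given here, compound 3 carries a methoxy group on that pyrimidine, a feature no measured pair tests. The step of a 1.0-fold lower number from compound 1 to compound 3 (0.00 log units; within the scatter) is therefore expected to stay within the scatter. Compound 3 is estimated at 75000 nM in this assay, with a range from 35000 nM to 160000 nM.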

Compound 3, half-maximal inhibitory concentration: 8800 nM
Estimate against measurement, compound 3: 8.5-fold (0.93 log units) above, and the stated range ends above it.
By their numbers in this assay, from the lowest: compound 3; then compounds 2 and 1 (each within the scatter of the next).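

The group on the sulfonamide nitrogen can change the result after all: the pyrimidin-2-yl swap earlier left the number unchanged within the scatter, whereas 5-methoxypyrimidin-2-yl in place of 3-methyl-1,2-oxazol-5-yl gives an 8.6-fold lower number from compound 1 to compound 3 (0.93 log units; beyond the scatter) in this assay. Compounds 2 and 3 differ only by methoxy in place of hydrogen on an aromatic carbon, and that single change gives an 8.5-fold lower number from compound 2 to compound 3 (0.93 log units; beyond the scatter), so the stronger result goes with the methoxy group and not with the pyrimidine ring alone. Nothing available explains why this methoxy group has this effect.

On these data alone, it remains open whether methoxy itself is needed, or whether a methyl, a chlorine or a longer ethoxy chain on the pyrimidine ring would give a similar step. An amine there is equally untested by the compounds shown.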